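The source may report more compounds than this note shows. Statements on the series, on what has been measured and on what is new or still open speak of the compounds shown alone.

Compound 1 `O=C(O)c1cccc([C@H]2C[C@@H](c3ccc(OCc4c(-c5c(Cl)cccc5Cl)noc4C4CC4)cc3Cl)C2)c1` gives 92 nM in an assay on HEK293 cells for agonist activity at Bile acid receptor (Homo sapiens); a lower number here means that less compound is needed, a higher number that more compound is needed for the effect.
Compound 2 `CCO[C@]1(c2ccc(OCc3c(-c4c(Cl)cccc4Cl)noc3C3CC3)cc2Cl)C[C@H](c2cccc(C(=O)O)c2)C1` gives 220 nM in this assay.
Compound 3 `O=C(O)c1cccc([C@H]2C[C@](OCCO)(c3ccc(OCc4c(-c5c(Cl)cccc5Cl)noc4C4CC4)cc3Cl)C2)c1` gives 377 nM in this assay.

Compound 3 stands apart from compound 1 by a 4.1-fold higher number from compound 1 to compound 3 (0.61 log units; beyond the scatter), while its gap to compound 2, a 1.7-fold higher number from compound 2 to compound 3 (0.23 log units; within the scatter), is within the scatter. Compound 4 `CO[C@]1(c2ccc(OCc3c(-c4c(Cl)cccc4Cl)noc3C3CC3)cc2Cl)C[C@H](c2cccc(C(=O)O)c2)C1` differs from compound 3 by hydrogen in place of hydroxymethyl on a saturated chain carbon bound to an oxygen on a saturated carbon. Among the measured compounds shown here, two measured steps bear on this: a 1.7-fold higher number from compound 2 to compound 3 (0.23 log units; within the scatter) shows that adding the hydroxy changed little, and a 2.4-fold higher number from compound 1 to compound 2 (0.38 log units; beyond the scatter) shows that a small alkoxy group on that carbon costs only a modest amount. Removing the hydroxymethyl is therefore expected to lower the number slightly, within the scatter, giving a step of a 1.6-fold lower number from compound 3 to compound 4 (0.21 log units; within the scatter). Compound 4 is expected to give about 230 nM in this assay, between 110 nM and 480 nM.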

Compound 4, half-maximal effective concentration: 102 nM
Beside the measured number, compound 4's estimate is 2.3-fold (0.35 log units) above it, outside the stated range (below it).
By their numbers in this assay, from the lowest: compounds 1 and 4 (each within the scatter of the next); then compounds 2 and 3 (each within the scatter of the next).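

In this assay methoxy in place of hydrogen on this saturated ring carbon leaves the number unchanged within the scatter, at a 1.1-fold higher number from compound 1 to compound 4 (0.04 log units; within the scatter) so an alkoxy group here need carry no cost. The cost appears only with the larger groups: going from ethoxy to methoxy gives a 2.2-fold lower number from compound 2 to compound 4 (0.33 log units; beyond the scatter) and going from 2-hydroxyethoxy to methoxy gives a 3.7-fold lower number from compound 3 to compound 4 (0.57 log units; beyond the scatter) so the earlier rises do not apply to every alkoxy group. No supporting evidence is available to explain this difference.

Going by these compounds, how a hydroxy group or an amine directly on that ring carbon would read remains open. So does whether a longer chain, such as propoxy, would raise the number further.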